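Ethyl for fluoro on the phenoxy cap of compound 2

The source may report more compounds than this note shows. Statements on the series, on what has been measured and on what is new or still open speak of the compounds shown alone.

Working notes on a small benzamide series tested in a functional assay on HepG2 cells (Homo sapiens) for antiproliferative activity, read by CCK-8 assay, with a stated time of 72 h; on this read-out lower numbers stand for stronger inhibition and higher numbers for weaker inhibition. Compound 1 `Nc1ccccc1NC(=O)/C=C/c1ccc(CN2CCc3ccccc32)cc1` gives only a limit in this assay, > 32000 nM, which is the limit of > 32000 nM in this assay, at which 1 of the 2 values shown sits, and therefore not a number. Compound 2 `Nc1ccccc1NC(=O)c1ccc(COc2ccc(F)cc2)cc1` is the one compound of the pair with a measured value: in this assay compound 2 gives 3840 nM, and it stands alone as the only number shown, so no step between measured compounds can be read from these data.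

The next compound, compound 3 `CCc1ccc(OCc2ccc(C(=O)Nc3ccccc3N)cc2)cc1`, differs from compound 2 in one place: ethyl in place of fluoro on an aromatic carbon, that is, 4-fluorophenyl to 4-ethylphenyl. Among the measured compounds shown here, no measured step bears on this kind of change here, so the step from compound 2 to compound 3 is expected to stay within the scatter, with no clear direction, as a 1.2-fold lower number from compound 2 to compound 3 (0.08 log units; within the scatter). Compound 3 is accordingly estimated at 3200 nM, between 1000 nM and 10000 nM.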

Compound 3, half-maximal inhibitory concentration: 6960 nM
Estimate against measurement, compound 3: 2.2-fold (0.34 log units) below; the measured number falls inside the stated range.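

Among the compounds shown here, the first step that can be read concerns the phenoxy cap: in this assay, ethyl in place of fluoro on an aromatic carbon gives a 1.8-fold higher number from compound 2 to compound 3 (0.26 log units; within the scatter). This position, para to a large group, therefore carries either ethyl or fluoro with no separation between the two compounds on this read-out. Nothing measured here accounts for the size of this step.

For the compounds shown here, still open is how an amine, a carboxylic acid or a longer chain such as butyl would read at this same position, since one step covers only this one exchange. Going by these compounds alone, compound 1 gives > 32000 nM, which is a limit of the assay and not a number, and no step from it to the other compounds can be read.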